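Ester to propyl ether: cytotoxicity notes

The source may report more compounds than this note shows. Statements on the series, on what has been measured and on what is new or still open speak of the compounds shown alone.

compound 1 `COc1ccc2oc(-c3csc4ccccc34)c(OC(=O)C(C)(C)C)c(=O)c2c1` | >= 12500 nM (a limit)
compound 2 `CCCCC(=O)Oc1c(-c2csc3ccccc23)oc2ccc(OC)cc2c1=O` | >= 12500 nM (a limit)

In an ADME assay on THP-1 cells (Homo sapiens) for cytotoxicity, read by MTT assay (on this read-out higher numbers stand for lower toxicity in this test and lower numbers for higher toxicity in this test), compound 2 gives >= 12500 nM as a limit, not a number. Within the data shown here, the series so far amounts to the limit of >= 12500 nM in this assay, at which 2 of the 2 values shown sit, and nothing finer. Compound 3 `CCCOc1c(-c2csc3ccccc23)oc2ccc(OC)cc2c1=O` carries propyl in place of butylcarbonyl on an oxygen on an aromatic ring, counted as propyl in place of butylcarbonyl on an oxygen on an aromatic ring in full. Among the measured compounds shown here, the only measured step is a step that the two limits leave unreadable from compound 1 to compound 2 and it concerns another change, so it supplies no size to carry over. With compound 2 at >= 12500 nM as the only starting point, no direction can be read for this change. The expected step is a number no higher from compound 2 to compound 3 (the limit leaves the size open) with no direction favoured. Compound 3 is estimated at 12500 nM with an expected range of 6000 nM to 30000 nM, and a limit is expected again.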

Compound 3, half-maximal cytotoxic concentration: >= 12500 nM
Compound 3: a limit, no number; the forecaster's own chance of this, stated with the estimate: 75%; the middle value lies on the limit itself.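

No step can be read among compound 1, compound 2 and compound 3, since all three values are limits and not numbers: the limit of >= 12500 nM in this assay, at which 3 of the 3 values shown sit.

Left open is how far each compound lies beyond its limit, and so whether either change on the shared core alters the read-out at all.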